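Isatin-type series: aryl group on the amide-side methylene

The source may report more compounds than this note shows. Statements on the series, on what has been measured and on what is new or still open speak of the compounds shown alone.

Measured so far in a functional assay on K562 cells (Homo sapiens) for antiproliferative activity, read by MTT assay, with a stated time of 48 h; on this read-out lower numbers stand for stronger inhibition and higher numbers for weaker inhibition:
- compound 1 `COc1ccc(-c2ccc3c(c2)C(=O)C(=O)N3Cc2cccc(OC)c2)cc1`: 680 nM
- compound 2 `COc1ccc(-c2ccc3c(c2)C(=O)C(=O)N3Cc2ccccc2OC)cc1`: 40 nM

Compound 2 gives the lowest of the two numbers. Within the data shown here, the single step between the measured compounds, a 17-fold lower number from compound 1 to compound 2 (1.23 log units; beyond the scatter), shows that the aryl group on the saturated chain carbon bound to the amide-type nitrogen in a ring has a large effect on this assay.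

Compound 3 `COc1ccc(-c2ccc3c(c2)C(=O)C(=O)N3Cc2ccc3ccccc3c2)cc1` differs from compound 2 by naphthalen-2-yl in place of 2-methoxyphenyl on a saturated chain carbon bound to an amide-type nitrogen in a ring. Among the measured compounds shown here, no measured pair covers an exchange of this kind: both measured compounds carry a methoxyphenyl at this position, and the step from compound 1 to compound 2 only moves the methoxy group within the phenyl ring. For the measured compounds named here, the change to naphthalen-2-yl therefore has no direct precedent here; the one step on record indicates only that this position is sensitive. The number for compound 3 is expected to be higher than for compound 2, with a wide range, as a 5.0-fold higher number from compound 2 to compound 3 (0.70 log units; beyond the scatter). Compound 3 is estimated at 200 nM, between 40 nM and 1000 nM.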

Compound 3, half-maximal inhibitory concentration: 400 nM
For compound 3 the middle estimate is 2.0-fold (0.30 log units) below the measured one, and the stated range covers the measured number.
By their numbers in this assay, from the lowest: compound 2; then compounds 3 and 1 (each within the scatter of the next).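

Notes on the aryl group on the saturated chain carbon bound to an amide-type nitrogen in a ring: in this assay, naphthalen-2-yl in place of 2-methoxyphenyl gives a 10-fold higher number from compound 2 to compound 3 (1.00 log units; beyond the scatter), so the low number of compound 2 does not carry over to this aryl group of carbon only. Measured against the 3-methoxyphenyl group, the same naphthalen-2-yl gives a 1.7-fold lower number from compound 1 to compound 3 (0.23 log units; within the scatter), a step within the scatter, so these two compounds cannot be separated on this read-out. Among the three groups, 2-methoxyphenyl alone stands apart, with its steps to both other compounds beyond the scatter, which shows that the position does not respond simply to the presence of a methoxy group or to the exchange of one aryl group for another.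

Still open, as far as these compounds go, is whether the methoxy oxygen matters here, which a plain phenyl, a 2-methylphenyl or a 2-hydroxyphenyl group at this place would help to decide. A 4-methoxyphenyl or a 2-ethoxyphenyl group would also show how narrow the preference for 2-methoxyphenyl is.

No measurement at hand accounts for these differences.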